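A few compounds are considered here, and "the series" means these few. Any claim that something is new, unique, unknown or untested is made for them only; others in the source may bear on it.

Measured so far in an ADME assay on the whole organism with Oryza sativa as the target, tested at 0.1 uM; a higher number here means a weaker effect of the compound at the concentration tested, a lower number a stronger effect:
compound 1, `Cc1ccccc1NC(=O)N[C@H](C)c1ccccc1`: 100%
compound 2, `Cc1ccccc1NC(=O)N[C@@H](C)c1ccccc1`: 100%
compound 3, `CC(=O)c1cccc(NC(=O)N[C@@H](C)c2ccccc2)c1`: 96%

Compound 2 stands level with compound 1 at the digits shown, the two together the highest of the three numbers, and compound 3 lies within the scatter of compound 2. Going by the values given here, the only counted step, no change at the digits printed from compound 1 to compound 2 (within the scatter), rests on the fact that compounds 1 and 2 differ only in the configuration as drawn and so says nothing about an exchange of groups on the aromatic ring. Compound 4, `C[C@H](NC(=O)Nc1ccccc1I)c1ccccc1`, differs from compound 2 by iodo in place of methyl on an aromatic carbon. Among the compounds with values here, no measured step covers such an exchange; compounds 2 and 3, for which no step is given, show values within the scatter of each other. A step of a number 2 percentage points lower from compound 2 to compound 4 (within the scatter) of no size beyond the scatter is therefore expected. Compound 4 is estimated at 98%, range 85% to 100%.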

Compound 4, a percentage reported as activity, at one concentration (the size of the read-out at that concentration, not a potency): 99%
For compound 4 the middle estimate is 1 percentage points below the measured one, within the range that was stated.
By their numbers in this assay, from the lowest: compounds 3, 4, 1 and 2 (each within the scatter of the next).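

Iodo in place of methyl on an aromatic carbon, ortho to a large group, gives a number 1 percentage points lower from compound 2 to compound 4 (within the scatter) in this assay. Going by these compounds alone, this is the first step that exchanges a group on the ring rather than a configuration, and it shows that this exchange at this position gives no step beyond the scatter. Nothing at hand bears on the reason for this step.

As far as these compounds go, whether an amine, a carboxylic acid or a longer chain at this position would give a step beyond the scatter remains open. Also open, from the compounds shown here alone, is whether any change to the shared core gives a clearly stronger effect in this assay.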